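Swapping Imidazole for Bromine in a Nitrofuran Chalcone

This account rests on a few compounds, and the source may have more. Where it says the series, first, only, none or still open, it means among the compounds named here.

Compound 1 `O=C(/C=C/c1ccc([N+](=O)[O-])o1)c1ccc(-n2ccnc2)cc1` was tested in an ADME assay on THP-1 cells (Homo sapiens) for cytotoxicity, read by resazurin assay, with a stated time of 72 h (on this read-out higher numbers stand for lower toxicity in this test and lower numbers for higher toxicity in this test), and gave 22200 nM. Of the two numbers reported, compound 1 stands lowest; compound 2 `O=C(/C=C/c1ccc([N+](=O)[O-])s1)c1ccc(-n2ccnc2)cc1` gives 23400 nM, and the gap between them lies within the scatter. Compound 3 `O=C(/C=C/c1ccc([N+](=O)[O-])cc1)c1ccc(N2CCCCC2)cc1` reached only the limit of this assay, > 50000 nM. Compound 4 `O=C(/C=C/c1ccc([N+](=O)[O-])o1)c1ccc(Br)cc1` has not yet been measured; it differs from compound 1 by bromo in place of 1H-imidazol-1-yl on an aromatic carbon. Among the compounds with values here, no measured pair in this set follows that change, so nothing here fixes its size. In this assay a step of no more than the scatter is expected, in either direction. Compound 4 is therefore expected to give 20000 nM, in a range from 8000 nM to 50000 nM. The step from compound 1 to compound 4 is estimated as a 1.1-fold lower number from compound 1 to compound 4 (0.05 log units; within the scatter).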

Compound 4, half-maximal cytotoxic concentration: 13400 nM
Compound 4: middle estimate off by 1.5-fold (0.17 log units), on the high side, and the stated range covers the measured number.
By their numbers in this assay, from the lowest: compounds 4, 1 and 2 (each within the scatter of the next). At a limit, above all of these: compound 3.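

In this assay, putting bromo in place of 1H-imidazol-1-yl on this aromatic carbon gives a 1.7-fold lower number from compound 1 to compound 4 (0.22 log units; within the scatter). At this position, then, a single bromine atom with no ring and no hydrogen-bond acceptors stands in for the whole five-membered aromatic ring without a step beyond the scatter. Nothing shown here points to a cause for this step. On these data alone, what remains open is whether a basic amine, a carboxylic acid or a longer alkyl chain at this same position would leave the number as little changed. As far as these compounds go, whether bromo would behave alike on the core of compound 2 is also open.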